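The source may report more compounds than this note shows. Statements on the series, on what has been measured and on what is new or still open speak of the compounds shown alone.

The measured compounds:
compound 1, `CC#C[C@H]1CN(S(=O)(=O)c2ccc(N)nc2)CCN1c1ccc(S(=O)(=O)NC)cn1`, 381 nM
compound 2, `CC#C[C@H]1CN(S(=O)(=O)c2ccc(N)nc2)CCN1c1ccc(S(=O)(=O)NCC2CC2)cc1`, 271 nM
compound 3, `CC#C[C@H]1CN(S(=O)(=O)c2ccc(N)nc2)CCN1c1ccc(C(O)(C(F)(F)F)C(F)(F)F)cn1`, 421 nM

In an assay on cells (Hepatocyte) for inhibition of glucokinase regulatory protein (Mus musculus), with stated times of 20 min and 40 min (on this read-out lower numbers stand for an effect already at smaller amounts and higher numbers for an effect only at larger amounts of compound), compound 2 gives the lowest of the three numbers, but compound 1 and compound 3 both lie within the scatter of it, so no order among the three can be read from these values. For the measured compounds named here, the one step in the set, a 1.1-fold higher number from compound 1 to compound 3 (0.04 log units; within the scatter), sits on the other aromatic ring of the shared core and shows that a complete exchange of the group there leaves the read-out unchanged within the scatter.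

Compound 4, `CC#C[C@H]1CN(S(=O)(=O)c2ccc(N)nc2)CCN1c1ccc([S+](C)[O-])cc1`, differs from compound 2 in one place: a group of 3 heavy atoms (1 carbon, 1 oxygen, 1 sulfur; no ring) in place of a group of 8 heavy atoms (4 carbon, 1 nitrogen, 2 oxygen, 1 sulfur; one three-membered non-aromatic ring of carbon only), on an aromatic carbon. Going by the values given here, no measured step touches this ring, so the only guidance is the indifference seen in a 1.1-fold higher number from compound 1 to compound 3 (0.04 log units; within the scatter). A modest rise in the number is nonetheless expected, since the group that leaves is much larger than the one that enters; the step from compound 2 to compound 4 is estimated as a 1.8-fold higher number from compound 2 to compound 4 (0.27 log units; within the scatter). Compound 4 is therefore expected to give 500 nM, within a range from 200 nM to 1300 nM.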

Compound 4, half-maximal effective concentration: > 12500 nM
Compound 4 ended at the assay's limit (the forecaster's own chance of this, stated with the estimate: 5%); at least 25-fold (1.39 log units) between middle value and limit.
By their numbers in this assay, from the lowest: compounds 2, 1 and 3 (each within the scatter of the next). At a limit, above all of these: compound 4.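

On the six-membered aromatic ring of carbon only, the group para to a large group is not interchangeable: in this assay, replacing (cyclopropylmethyl)sulfamoyl with the group of compound 4 gives an at least 46-fold higher number from compound 2 to compound 4 (1.66 log units; beyond the scatter), a large change beyond the scatter. The value of compound 4 is a limit of the assay and not a number: the limit of > 12500 nM in this assay, at which 1 of the 4 values shown sits. For the compounds shown here, this is the first change in the set to move the read-out beyond the scatter, so the indifference of a 1.1-fold higher number from compound 1 to compound 3 (0.04 log units; within the scatter) does not extend to this exchange on this ring.

The compounds shown do not separate the loss of the cyclopropylmethyl part from the exchange of the sulfamoyl part, as both change in this single step. From the compounds shown here alone, how an amine or a carboxylic acid at this aromatic carbon would read remains open.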